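The compounds below may be only part of what the source reports. "The series", "measured", "known", "first", "only" and "open" are said of these compounds alone.

Measured compounds in a functional assay (spleen, spleen) for activation, with Mus musculus as the target; on this read-out lower numbers stand for an effect already at smaller amounts and higher numbers for an effect only at larger amounts of compound:
- compound 1 `COc1cccc(Cn2c(O)nc3c(N)ncnc32)c1`: in this assay compound 1 gives 10 uM
- compound 2 `CCSc1nc(N)c2nc(O)n(Cc3ccccc3)c2n1`: in this assay compound 2 gives 0.1 uM
- compound 3 `Nc1ncnc2c1nc(S)n2Cc1ccccc1`: in this assay compound 3 gives 10 uM

Compound 2 stands at the lowest number of the three; compound 1 and compound 3 each sit well above it, and both gaps lie beyond the scatter, so compound 2 is the most potent of the measured set. Among the compounds with values here, no pair of these three differs in a single place, so no single step can be read off them.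

Compound 4 `CCCc1nc(N)c2nc(O)n(Cc3ccccc3)c2n1` has not yet been measured. Relative to compound 2 the change is propyl in place of ethylsulfanyl on an aromatic carbon. The three measured values give no direct guide to exchanging ethylsulfanyl for propyl at this aromatic carbon; the two groups match in heavy-atom count and differ only in the sulfur and its acceptor. Compound 4 is therefore expected to stay close to compound 2, with a small step toward higher numbers judged most likely, though a step within the scatter cannot be ruled out. The step expected from compound 2 to compound 4 is a 3.0-fold higher number from compound 2 to compound 4 (0.48 log units; beyond the scatter). Compound 4 is estimated at 0.3 uM in this assay, within a range of 0.05 uM to 2 uM.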

Compound 4, minimum effective concentration: 1 uM
The estimate for compound 4 lay 3.3-fold (0.52 log units) below the measured number, within the range that was stated.
By their numbers in this assay, from the lowest: compound 2; then compound 4; then compounds 1 and 3 (each within the scatter of the next).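

In this assay, within the data shown here, propyl in place of ethylsulfanyl on the aromatic carbon between two ring nitrogen atoms gives a 10-fold higher number from compound 2 to compound 4 (1.00 log units; beyond the scatter), the first single-place step, and it lies beyond the scatter. This position therefore does not tolerate the exchange without loss, even though both groups carry 3 heavy atoms and neither has a ring, a hydrogen-bond donor or a net charge. The counted differences are limited to the sulfur atom and the 1 hydrogen-bond acceptor of ethylsulfanyl, but nothing shown accounts for the step.

Going by these compounds, it remains open whether the step follows the sulfur atom or is specific to propyl, and an ethoxy group, a methylsulfanyl group, a butyl chain or an amine on the same carbon would help to separate these readings. Also open, on these data alone, is whether the exchange gives a step of similar size when the group on the ring nitrogen of the shared core is changed.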